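The compounds below may be only part of what the source reports. "The series", "measured", "known", "first", "only" and "open" are said of these compounds alone.

Compound 1 `CCNC(=O)CCc1cccc2c1B(O)OC2` gives > 100000 nM in a functional assay on SK-OV-3 cells (Homo sapiens) for antiproliferative activity, read by MTT assay, with a stated time of 72 h (on this read-out higher numbers stand for weaker inhibition and lower numbers for stronger inhibition), which is a limit of the assay rather than a number.
Compound 2 `CC(C)(C)NC(=O)CCc1cccc2c1B(O)OC2` gives > 100000 nM in this assay, again a limit rather than a number.
Compound 3 `O=C(CCc1cccc2c1B(O)OC2)Nc1ccccc1` gives 200 nM in this assay.

Compound 3 is therefore the only compound with a number shown; the other two values sit at the limit of > 100000 nM in this assay, at which 2 of the 3 values shown sit. The measured steps all concern the group on the amide nitrogen: putting phenyl in place of ethyl gives an at least 500-fold lower number from compound 1 to compound 3 (2.69 log units; beyond the scatter), and putting phenyl in place of tert-butyl gives an at least 500-fold lower number from compound 2 to compound 3 (2.69 log units; beyond the scatter), while the change from ethyl to tert-butyl is a step that the two limits leave unreadable from compound 1 to compound 2.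

Compound 4 `COc1cc(OC)cc(-c2cccc(NC(=O)CCc3cccc4c3B(O)OC4)c2)c1` keeps the phenyl amide of compound 3 and adds to it: 3,5-dimethoxyphenyl in place of hydrogen on an aromatic carbon. Going by the values given here, none of the measured steps touches a substituent on that aromatic ring; they only contrast an alkyl group with an aryl group on the nitrogen, and compound 3 already carries the aryl group. There is thus no measured step that shows what a further ring on the phenyl does, and no reason from the data to expect a step beyond the scatter in this assay.

The expected step in this assay is a 1.3-fold lower number from compound 3 to compound 4 (0.12 log units; within the scatter). Compound 4 is therefore estimated at 150 nM in this assay, within a range from 30 nM to 800 nM.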

Compound 4, half-maximal inhibitory concentration: 44 nM
Estimate against measurement, compound 4: 3.4-fold (0.53 log units) above, and the stated range covers the measured number.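

Going by these compounds alone, compound 4 shows that the aromatic ring of the phenyl amide can carry a large substituent without losing activity, which the earlier compounds could not show, as they differ only in the group on the amide nitrogen. In this assay, placing 3,5-dimethoxyphenyl on an aromatic carbon of that ring, meta to a large group, gives a 4.5-fold lower number from compound 3 to compound 4 (0.66 log units; beyond the scatter). The step is modest but real, so this position is not merely tolerated and can lower the number further, although nothing shown here accounts for why the added ring has this effect.

The compounds shown leave open whether the gain comes from the added ring itself or from its methoxy groups, a question that a plain phenyl or a single methoxy group at the same place would help to settle. Also open, as far as these compounds go, is what an amine or a carboxylic acid on the added ring would do, and whether the ring would give a similar number on another carbon of the phenyl amide.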